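Expected Cell Tolerance of Compound 4

The compounds below may be only part of what the source reports. "The series", "measured", "known", "first", "only" and "open" are said of these compounds alone.

Compound 1 `O=C(COc1cccc2ccccc12)N/N=C/c1ccc(O)cc1`: 26.5 ug/mL
Compound 2 `COc1ccc(/C=N/NC(=O)COc2cccc3ccccc23)cc1OC`: 14.7 ug/mL
Compound 3 `COc1ccc(/C=N/NC(=O)COc2cccc3ccccc23)cc1O`: 7.05 ug/mL

Three compounds were measured in an ADME assay on MT4 cells (Homo sapiens) for cytotoxicity, read by MTT assay, with a stated time of 4 days; a higher number here means that more compound is tolerated, a lower number that less compound is tolerated. Compound 1 stands highest of the three; compound 2 lies nearest, within the scatter of compound 1, while compound 3 lies furthest, beyond the scatter. Going by the values given here, the only single-change step among them, a 2.1-fold lower number from compound 2 to compound 3 (0.32 log units; beyond the scatter), concerns the removal of a methyl from an oxygen and does not touch the part that is altered here. Compound 4 `O=C(COc1cccc2ccccc12)N/N=C/C=C/c1ccccc1` differs from compound 1 by 2-phenylethenyl in place of 4-hydroxyphenyl on a carbon with a double bond to nitrogen. Among the compounds with values here, no measured step bears directly on this change, so no step beyond the scatter is expected, and the expected step is a 1.3-fold lower number from compound 1 to compound 4 (0.12 log units; within the scatter). For compound 4 the value in this assay is estimated at 20 ug/mL, within a range from 8 ug/mL to 50 ug/mL.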

Compound 4, half-maximal cytotoxic concentration: 82.7 ug/mL
The estimate for compound 4 lay 4.1-fold (0.62 log units) below the measured number; measured number above the stated range.
By their numbers in this assay, from the lowest: compound 3; then compounds 2 and 1 (each within the scatter of the next); then compound 4.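

In this assay, 2-phenylethenyl in place of 4-hydroxyphenyl on a carbon with a double bond to nitrogen brings a 3.1-fold higher number from compound 1 to compound 4 (0.49 log units; beyond the scatter) and puts compound 4 above all the others shown. Going by these compounds alone, the one earlier step left this place untouched, so this is the first sign that a change here can move the number beyond the scatter. Nothing at hand explains the rise.

The change removes the hydroxyl and adds a double bond outside the ring together, and the compounds shown do not separate the two. A plain phenyl or a 2-phenylethyl group in this place would tell them apart.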